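The source may report more compounds than this note shows. Statements on the series, on what has been measured and on what is new or still open speak of the compounds shown alone.

In an assay on microsomes from liver for inhibition of sterol O-acyltransferase 1 (Rattus norvegicus) (on this read-out lower numbers stand for stronger inhibition and higher numbers for weaker inhibition), compound 1 `C[C@]1(O)CC(=O)OC(CSc2nc(-c3ccccc3)c(-c3ccccc3)[nH]2)C1` gives 140 nM. Compound 2 `C[C@@]1(O)CC(=O)OC(CSc2nc(-c3ccccc3Cl)c(-c3ccccc3Cl)[nH]2)C1` gives 140 nM in this assay, so compound 1 stands level with compound 2 within the scatter, and no order between the two can be drawn. Compound 3 `O=C1CC(O)CC(CSc2nc(-c3ccccc3)c(-c3ccccc3)[nH]2)O1` differs from compound 1 by a group of 8 heavy atoms (5 carbon, 3 oxygen; one six-membered non-aromatic ring with 1 hetero atom) in place of a group of 9 heavy atoms (6 carbon, 3 oxygen; one six-membered non-aromatic ring with 1 hetero atom), on a saturated chain carbon bound to a sulfur. Within the data shown here, no measured pair covers this change, so its size is not known from the data; the step from compound 1 to compound 3 is expected to be a 1.4-fold higher number from compound 1 to compound 3 (0.15 log units; within the scatter), a modest weakening or none beyond the scatter. Compound 3 is therefore estimated at 200 nM, with a range from 70 nM to 600 nM.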

Compound 3, half-maximal inhibitory concentration: 910 nM
Estimate against measurement, compound 3: 4.6-fold (0.66 log units) below; measured number outside the range, above it.
By their numbers in this assay, from the lowest: compounds 1 and 2 (each within the scatter of the next); then compound 3.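

In this assay this place, on a saturated chain carbon bound to a sulfur, proves sensitive to a small change in the group: the replacement gives a 6.5-fold higher number from compound 1 to compound 3 (0.81 log units; beyond the scatter). The two groups share one six-membered non-aromatic ring with 1 hetero atom and the same donor and acceptor counts, but the group that enters has one carbon fewer and no defined stereocentre, where the group that leaves has 1. No measurement at hand bears on the reason for this step. Which of these two differences carries the step stays open. So does whether a group holding an amine or a carboxylic acid in this place would lie nearer compound 1 or compound 3.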